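The compounds below may be only part of what the source reports. "The series", "measured", "known", "first", "only" and "open" are said of these compounds alone.

In a functional assay for antagonist activity at G-protein coupled receptor 52 (Mus musculus) (on this read-out higher numbers stand for weaker inhibition and lower numbers for stronger inhibition), two compounds have been measured:
compound 1 `O=C(/C=C/CCc1ccccc1)CCc1ccccc1` gives 6000 nM;
compound 2 `O=C(/C=C/CCc1ccccc1)c1ccccc1` gives 650 nM.

Compound 2 stands lowest of these two numbers, and the gap to compound 1 lies well beyond the usual scatter. Compound 3 `O=C(/C=C/CCc1ccccc1)c1cccs1` has not yet been measured. The change from compound 2 is thiophen-2-yl in place of phenyl on a carbonyl carbon. No measured pair among these compounds shows such an exchange, so in this assay no step beyond the scatter is expected, in either direction. The expected step is a 1.2-fold higher number from compound 2 to compound 3 (0.06 log units; within the scatter). Compound 3 is therefore estimated at 750 nM, with a range from 250 nM to 2500 nM.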

Compound 3, half-maximal inhibitory concentration: 630 nM
Compound 3: middle estimate off by 1.2-fold (0.08 log units), on the high side; the range from low to high includes it.
By their numbers in this assay, from the lowest: compounds 3 and 2 (each within the scatter of the next); then compound 1.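

In this assay thiophen-2-yl in place of phenyl on a carbonyl carbon gives a 1.0-fold lower number from compound 2 to compound 3 (0.01 log units; within the scatter) and so leaves the read-out unchanged within the scatter. This one exchange shows that the position accepts a five-membered aromatic ring containing sulfur as well as a six-membered aromatic ring of carbon only. No measurement at hand offers an explanation for this match.

Still open, going by these compounds, is whether a furan-2-yl or pyridin-2-yl ring on this carbonyl carbon would read the same. Also open, on these data alone, is how either ring would behave carrying an amine or a carboxylic acid.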